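The source may report more compounds than this note shows. Statements on the series, on what has been measured and on what is new or still open speak of the compounds shown alone.

Measured in a functional assay on BGC-823 cells (Homo sapiens) for antiproliferative activity, read by MTT assay, with a stated time of 24 h; a lower number here means a stronger inhibitor, a higher number a weaker inhibitor:
compound 1 `c1ccc(CSc2nnc(-c3ccc4c(c3)OCCO4)n2-c2ccccc2)cc1`: 73400 nM
compound 2 `COc1cccc(CSc2nnc(-c3ccc4c(c3)OCCO4)n2-c2ccccc2)c1`: > 100000 nM, a limit of the assay and not a number
compound 3 `Fc1ccccc1CSc1nnc(-c2ccc3c(c2)OCCO3)n1-c1ccccc1`: 18600 nM

Compound 3 holds the lowest number shown, through a 3.9-fold lower number from compound 1 to compound 3 (0.60 log units; beyond the scatter) and an at least 5.3-fold lower number from compound 2 to compound 3 (0.73 log units; beyond the scatter). Compound 4 `Brc1ccc(CSc2nnc(-c3ccc4c(c3)OCCO4)n2-c2ccccc2)cc1` has 4-bromophenyl in place of 2-fluorophenyl on a saturated chain carbon bound to a sulfur. For the measured compounds named here, two measured steps bear on this change, both of them substitutions on the same benzyl ring: a 3.9-fold lower number from compound 1 to compound 3 (0.60 log units; beyond the scatter) with fluoro and an at least 1.3-fold higher number from compound 1 to compound 2 (0.13 log units; that floor lies within the scatter) with methoxy. Going by the values given here, compound 4 gives up the fluoro group behind the first of these, and no measured step covers bromo. A modest move back toward compound 1 is therefore expected, as a 2.3-fold higher number from compound 3 to compound 4 (0.35 log units; beyond the scatter). Compound 4 is estimated at 42000 nM, within a range of 14000 nM to 100000 nM.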

Compound 4, half-maximal inhibitory concentration: 33800 nM
Compound 4: middle estimate off by 1.2-fold (0.09 log units), on the high side, and the stated range covers the measured number.
By their numbers in this assay, from the lowest: compounds 3 and 4 (each within the scatter of the next); then compound 1. At a limit, above all of these: compound 2.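

Bromo joins fluoro as a second substituent on the benzyl ring that lowers the number, with a 2.2-fold lower number from compound 1 to compound 4 (0.34 log units; beyond the scatter), while methoxy in compound 2 goes against any general gain from substitution. Replacing 2-fluorophenyl with 4-bromophenyl gives a 1.8-fold higher number from compound 3 to compound 4 (0.26 log units; within the scatter), so these two groups are not told apart here, whereas an at least 2.9-fold lower number from compound 2 to compound 4 (0.47 log units; beyond the scatter) is only a floor. Compound 2 stands at a limit of the assay and not a number: the limit of > 100000 nM in this assay, at which 1 of the 4 values shown sits.

The compounds shown leave open whether the halogen itself or its place on the ring matters, since fluoro and bromo differ in both. Going by these compounds, how a benzyl ring carrying an amine or a carboxylic acid would read also remains open.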